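The source may report more compounds than this note shows. Statements on the series, on what has been measured and on what is new or still open speak of the compounds shown alone.

Values so far in a functional assay on V79 cells (Cricetulus griseus) for cytotoxicity, read by colony formation; on this read-out lower numbers stand for stronger inhibition and higher numbers for weaker inhibition
- compound 1 (`O=C(O)c1cn(C2CC2)c2c(C(F)(F)F)c(N3CCCC3)c(F)cc2c1=O`) gives 280 ug/mL
- compound 2 (`NCC1CCN(c2c(F)cc3c(=O)c(C(=O)O)cn(C4CC4)c3c2Cl)C1`) gives 8 ug/mL

Compound 2 holds the lower of the two numbers, beyond the scatter from compound 1. Compound 3 (`NCC1CCN(c2c(F)cc3c(=O)c(C(=O)O)cn(C4CC4)c3c2C(F)(F)F)C1`) has trifluoromethyl in place of chloro on an aromatic carbon. Among the compounds with values here, no measured step isolates this change. Within the data shown here, the only guide is compound 1, which also carries trifluoromethyl and gives 280 ug/mL in this assay, so a moderately higher number is expected. The expected move is a 3.1-fold higher number from compound 2 to compound 3 (0.49 log units; beyond the scatter) and is an estimate only. For compound 3 the estimated value is 25 ug/mL with an expected range of 6 ug/mL to 100 ug/mL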

Compound 3, half-maximal inhibitory concentration: 38 ug/mL
Beside the measured number, compound 3's estimate is 1.5-fold (0.18 log units) below it; low and high end bracket the measured number.
By their numbers in this assay, from the lowest: compound 2; then compound 3; then compound 1.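

In this assay, within the data shown here, trifluoromethyl in place of chloro on the aromatic carbon ortho to a 3-(aminomethyl)pyrrolidin-1-yl group gives a 4.8-fold higher number from compound 2 to compound 3 (0.68 log units; beyond the scatter), the only isolated reading of this change. With trifluoromethyl common to both compounds, aminomethyl in place of hydrogen on a saturated ring carbon gives a 7.4-fold lower number from compound 1 to compound 3 (0.87 log units; beyond the scatter), so this substituent also shifts the number beyond the scatter. No measured evidence accounts for either step.

On these data alone, whether the aminomethyl step holds with chloro on the aromatic carbon remains open. So does the effect of a methoxy group or a nitrile at that carbon.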